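The source may report more compounds than this note shows. Statements on the series, on what has been measured and on what is new or still open speak of the compounds shown alone.

The series shares one core, seen in compound 1 `COc1ccc(-c2c(Br)c(=O)c3c(OC)cc(OC)cc3n2S(=O)(=O)c2ccc(OC)cc2)cc1`. In a functional assay on SUP-B15 cells (Homo sapiens) for antiproliferative activity, with a stated time of 72 h (a higher number here means that more compound is needed for the effect, a lower number that less compound is needed), compound 1 gives 2920 nM, the only numerical result obtained among the three measured compounds. Compound 2 `COC(=O)c1cc(=O)c2cc(N)ccc2[nH]1` reaches only a limit in this assay, > 67200 nM. Compound 3 `COc1ccc(-c2cc(=O)c3c(OC)cc(OC)cc3n2S(=O)(=O)c2cc(Cl)cc(Cl)c2O)cc1` likewise reaches only a limit in this assay, > 37900 nM. The step of interest leads from compound 1 to compound 4 `COc1ccc(-c2cc(=O)c3c(OC)cc(OC)cc3n2S(=O)(=O)c2ccc(OC)cc2)cc1`, which has yet to be tested in this assay. The change is hydrogen in place of bromo on an aromatic carbon. Going by the values given here, no measured pair differing at a single position exists here, so the direction of this step must be anticipated from the structures alone. Compound 3 also lacks the bromo group, though it carries a different sulfonyl substituent, and it stands at a limit in this assay. Compound 4 is therefore expected to give an estimated 12000 nM in this assay, with a range from 2500 nM to 50000 nM. The expected step is a 4.1-fold higher number from compound 1 to compound 4 (0.61 log units; beyond the scatter), a loss of potency beyond the usual scatter.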

Compound 4, half-maximal effective concentration: > 82700 nM
Compound 4 ended at the assay's limit; the forecaster's own chance of this, stated with the estimate: 35%; at least 6.8-fold (0.83 log units) between middle value and limit.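

With the bromo group on this aromatic carbon the core of compound 1 gives a numerical result in this assay, whereas with hydrogen there it does not, and the step is an at least 28-fold higher number from compound 1 to compound 4 (1.45 log units; beyond the scatter). This is the first pair among the compounds shown that differs in one place, so the weight of the bromo group at this position, ortho to a 4-methoxyphenyl group, is now seen directly rather than across a changed sulfonyl substituent. The full size of the loss stays unknown, as compound 4 stands at a limit: the limit of > 82700 nM in this assay, at which 1 of the 4 values shown sits.

The step that changes the sulfonyl substituent cannot be read, with limits at both ends. Going by these compounds, what a chloro, methyl or nitrile group would give on this aromatic carbon stays open, and so does whether any group but bromo restores a measurable result.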